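Swapping the aryl group on the hydrazone carbon

The source may hold more compounds than are shown below. What is called first, only, known or untested is meant among the compounds shown, and "the series" means these compounds.

Of the compounds shown here, two built on the same core have been measured for their ability to kill colon cancer cells. Compound 1 `COc1ccc(OC)c(/C=N/NC(=O)Nc2ccc(Oc3ccnc(-c4nncn4CCN(C)C)c3)c(F)c2)c1` gives 2070 nM in a functional assay on HT-29 cells (Homo sapiens) for cytotoxicity, read by MTT assay, with a stated time of 72 h; on this read-out lower numbers stand for stronger inhibition and higher numbers for weaker inhibition. Compound 2 `CN(C)CCn1cnnc1-c1cc(Oc2ccc(NC(=O)N/N=C/c3ccc(O)c(Br)c3)cc2F)ccn1` gives 450 nM in this assay, which is the lowest of the two numbers, with compound 1 the nearest neighbour at a higher number.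

Among the compounds with values here, the single step available, a 4.6-fold lower number from compound 1 to compound 2 (0.66 log units; beyond the scatter), shows that changing the aryl group on the carbon with a double bond to nitrogen can move the number by more than the scatter.

Compound 3 `CN(C)CCn1cnnc1-c1cc(Oc2ccc(NC(=O)N/N=C/c3ccccc3O[N+](=O)[O-])cc2F)ccn1` changes that same position: 2-(nitrooxy)phenyl in place of 3-bromo-4-hydroxyphenyl on a carbon with a double bond to nitrogen. The group that leaves carries a hydroxyl donor and a bromine, while the group that enters carries a nitrooxy group and no donor. The step from compound 1 to compound 2 bears on this change only in that it marks the position as sensitive; it does not say which direction a nitrooxyphenyl will take. Given that the move away from 2,5-dimethoxyphenyl helped, a move away from 3-bromo-4-hydroxyphenyl is expected to cost some of that gain, though the direction stays uncertain.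

Compound 3 is therefore expected to show a 3.3-fold higher number from compound 2 to compound 3 (0.52 log units; beyond the scatter) in this assay. The estimate for compound 3 is 1500 nM, with a range from 400 nM to 5000 nM.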

Compound 3, half-maximal inhibitory concentration: 950 nM
The estimate for compound 3 lay 1.6-fold (0.20 log units) above the measured number; low and high end bracket the measured number.
By their numbers in this assay, from the lowest: compound 2; then compound 3; then compound 1.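

The position tolerates more than one kind of aryl group: in this assay, 2-(nitrooxy)phenyl gives a 2.2-fold lower number from compound 1 to compound 3 (0.34 log units; beyond the scatter), yet a 2.1-fold higher number from compound 2 to compound 3 (0.32 log units; beyond the scatter), so the three groups now fall into a clear order, with all gaps beyond the scatter. A hydrogen-bond donor on this aryl group is therefore not required for a number lower than that of compound 1, since the 2-(nitrooxy)phenyl group of compound 3 has none, although the group with the lowest number, the 3-bromo-4-hydroxyphenyl of compound 2, does carry one. No measurement shown here explains why the groups fall in this order.

On these data alone, the hydroxyl and the bromine leave together in the step to compound 3, so their separate contributions stay unknown, and 4-hydroxyphenyl and 3-bromophenyl groups would be the direct way to tell them apart. As far as these compounds go, it also remains open whether the nitrooxy group itself matters or whether a plain phenyl, a nitro group or an amine on the same ring would give a similar number.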